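A few compounds are considered here, and "the series" means these few. Any claim that something is new, unique, unknown or untested is made for them only; others in the source may bear on it.

Of the compounds shown here, three built on one shared core have been tested in an ADME assay on HepG2 cells (Homo sapiens) for cytotoxicity, read by luminescence, CellTiter-Glo and ATP content, with a stated time of 72 h; on this read-out higher numbers stand for an effect only at larger amounts of compound and lower numbers for an effect already at smaller amounts. Compound 1 `COc1ccc(F)cc1CNCCCNc1ccnc2cc(Cc3ccc(C#N)cc3)ccc12` gives 6050 nM. Compound 2 `COc1cccc(CNCCCNc2ccnc3cc(Oc4ccccc4)ccc23)c1O` gives 6800 nM, and compound 3 `COc1cccc(CNCCCNc2ccnc3cc(Cc4ccc(C#N)cc4)ccc23)c1O` gives 7150 nM. Compound 1 thus stands among three numbers that lie close together: the step from it is a 1.2-fold higher number from compound 1 to compound 3 (0.07 log units; within the scatter), and the values of compound 1 and compound 2 sit similarly close. Compound 4 `COc1ccc(F)cc1CNCCCNc1ccnc2cc(CC(C)C)ccc12` has not yet been measured. It differs from compound 1 in one place: isopropyl in place of 4-cyanophenyl on a saturated chain carbon bound to an aromatic carbon. Going by the values given here, of the measured steps, the one exchanging a group at the same end of the core is the step with 4-cyanobenzyl in place of phenoxy on an aromatic carbon, which came out as a 1.1-fold higher number from compound 2 to compound 3 (0.02 log units; within the scatter). The step from compound 1 to compound 3 concerns the other end of the molecule and gives no guidance here. Since one exchange at this end left this assay unchanged, no step beyond the scatter is expected in either direction. Compound 4 is therefore estimated at 6000 nM, with a range from 2500 nM to 15000 nM. This estimate corresponds to an expected step of a 1.0-fold lower number from compound 1 to compound 4 (0.00 log units; within the scatter).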

Compound 4, half-maximal effective concentration: 2900 nM
The estimate for compound 4 lay 2.1-fold (0.32 log units) above the measured number; low and high end bracket the measured number.
By their numbers in this assay, from the lowest: compound 4; then compounds 1, 2 and 3 (each within the scatter of the next).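

Going by these compounds alone, on a saturated chain carbon bound to an aromatic carbon, isopropyl in place of 4-cyanophenyl gives the only step beyond the scatter so far in this assay (a 2.1-fold lower number from compound 1 to compound 4 (0.32 log units; beyond the scatter)), so the cell effect here appears at a smaller amount of compound. The earlier exchange at this end of the molecule stayed within the scatter (a 1.1-fold higher number from compound 2 to compound 3 (0.02 log units; within the scatter)), so this end does respond to at least one change, though the step is modest. Nothing measured here explains the shift.

The change removes the benzene ring and the nitrile together, so plain benzyl would be needed to separate the two. As far as these compounds go, it also remains open whether a longer chain such as n-hexyl would give a number closer to compound 4 or to compound 1.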